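The source may hold more compounds than are shown below. What is called first, only, known or untested is meant among the compounds shown, and "the series" means these compounds.

Working notes on the series. In a functional assay on HeLa cells (Homo sapiens) for antiproliferative activity, read by CCK-8 assay, with a stated time of 48 h (on this read-out lower numbers stand for stronger inhibition and higher numbers for weaker inhibition), compound 1 (`COc1ccc(/C=C\c2cc(OC)c(OC)c(OC)c2)cc1OCc1ccc(CN2CCCC[C@@H]2C(=O)O)cc1`) gives > 10000 nM, which is a limit of the assay and not a number, so this limit is all that places compound 1 among the values shown.

Compound 2 (`COc1ccc(/C=C\c2cc(OC)c(OC)c(OC)c2)cc1OCc1ccc(CN2CCCCC2C(=O)O)cc1`) has the same atoms and bonds, drawn without a configuration at the saturated ring carbon, and gives 14200 nM. The comparison is a step that the limit leaves unreadable from compound 1 to compound 2, so it supplies no size. Compound 3 (`COc1ccc(/C=C\c2cc(OC)c(OC)c(OC)c2)cc1OCc1ccc(CN2CCCCC2C(=O)NCCNC(=O)OC(C)(C)C)cc1`) gives 2000 nM. Here the hydroxy on the carbonyl carbon is replaced by (2-((tert-butoxycarbonyl)amino)ethyl)amino, and the result is a 7.1-fold lower number from compound 2 to compound 3 (0.85 log units; beyond the scatter).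

Compound 4 (`COc1ccc(/C=C\c2cc(OC)c(OC)c(OC)c2)cc1OCc1ccc(CO)cc1`) differs from compound 1 by hydroxy in place of 2-carboxypiperidin-1-yl on a saturated chain carbon bound to an aromatic carbon, which places hydroxy on a saturated chain carbon bound to an aromatic carbon. Within the data shown here, the whole 2-carboxypiperidin-1-yl group leaves, and no measured step removes it. Among the measured compounds shown here, the nearest guide is compound 3, where replacing the hydroxy of the carboxy group gave the only readable step, with a value of 2000 nM. On that basis, a lower number than the limit of compound 1 is expected in this assay, at a size beyond the scatter but poorly fixed. The expected change is an at least 11-fold lower number from compound 1 to compound 4 (1.04 log units; beyond the scatter). The estimate for compound 4 is 900 nM, with an expected range of 100 nM to 6000 nM.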

Compound 4, half-maximal inhibitory concentration: 7600 nM
Beside the measured number, compound 4's estimate is 8.4-fold (0.93 log units) below it, outside the stated range (above it).
By their numbers in this assay, from the lowest: compound 3; then compounds 4 and 2 (each within the scatter of the next).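

In this assay, hydroxy in place of 2-carboxypiperidin-1-yl on a saturated chain carbon bound to an aromatic carbon gives a 1.9-fold lower number from compound 2 to compound 4 (0.27 log units; within the scatter), so compounds 2 and 4 cannot be told apart. At this place, the whole 2-carboxypiperidin-1-yl group, with its six-membered ring and defined stereocentre in compound 1, can therefore leave without a change beyond the scatter when the comparison is made with compound 2. Compound 1 stands at a limit of the assay and not a number, and the step from it is only a floor, an at least 1.3-fold lower number from compound 1 to compound 4 (0.11 log units; that floor lies within the scatter), because of that limit: the limit of > 10000 nM in this assay, at which 1 of the 4 values shown sits.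

The compounds shown leave open whether a plain piperidin-1-yl without the carboxylic acid, or a primary amine, on the same saturated chain carbon would give a step beyond the scatter from compound 4. Also open, as far as these compounds go, is whether the configuration at the saturated ring carbon counts at all, and whether a 7.1-fold lower number from compound 2 to compound 3 (0.85 log units; beyond the scatter) would hold with a free primary amine in place of the tert-butoxycarbonyl-protected one.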